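The compounds below may be only part of what the source reports. "The series", "measured", "known", "first", "only" and "open" are said of these compounds alone.

The three compounds measured so far:
compound 1 `CCN(CC)c1ccc2cc(C(=O)c3ccc(N4CCN(C(=O)CN5CCN(C(=O)CCl)CC5)CC4)cc3)oc2c1`, 5520 nM
compound 2 `CCN(CC)c1ccc2cc(C(=O)c3ccc(N4CCN(C(=O)CN5CCN(C(=O)/C=C/c6ccccc6)CC5)CC4)cc3)oc2c1`, 5260 nM
compound 3 `CCN(CC)c1ccc2cc(C(=O)c3ccc(N4CCN(C(=O)CN5CCN(Cc6ccc(/C=C/C(=O)OC)cc6)CC5)CC4)cc3)oc2c1`, 3040 nM

All three share one core and were tested in a functional assay on HeLa cells (Homo sapiens) for cytotoxicity, read by MTT assay, with a stated time of 48 h; a lower number here means a stronger inhibitor, a higher number a weaker inhibitor. Compound 3 gives the lowest of the three numbers, but its gaps to compound 2 and to compound 1 both lie within the scatter, so no order can be read from them. Compound 4 `CCN(CC)c1ccc2cc(C(=O)c3ccc(N4CCN(C(=O)CN5CCN(Cc6ccc(F)c(F)c6)CC5)CC4)cc3)oc2c1` differs from compound 3 in one place: 3,4-difluorophenyl in place of 4-(2-(methoxycarbonyl)ethenyl)phenyl on a saturated chain carbon bound to an amine nitrogen in a ring. Going by the values given here, the only measured single step, a 1.0-fold lower number from compound 1 to compound 2 (0.02 log units; within the scatter), concerns a different position and stayed flat; no measured step bears directly on this change. With all three values within the scatter of one another, the expected step is a 1.3-fold higher number from compound 3 to compound 4 (0.12 log units; within the scatter), no more than the scatter. Compound 4 is therefore estimated at 4000 nM, with a range from 1500 nM to 10000 nM.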

Compound 4, half-maximal inhibitory concentration: 6400 nM
Estimate against measurement, compound 4: 1.6-fold (0.20 log units) below; measured number inside the range.
By their numbers in this assay, from the lowest: compounds 3, 2, 1 and 4 (each within the scatter of the next, the first and the last beyond it).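

In this assay, going by these compounds alone, this position gives the first step beyond the scatter, though a modest one (a 2.1-fold higher number from compound 3 to compound 4 (0.32 log units; beyond the scatter)), so 3,4-difluorophenyl and 4-(2-(methoxycarbonyl)ethenyl)phenyl are not interchangeable on this saturated chain carbon. The steps that change the group on the amine nitrogen in a ring stay within the scatter (a 1.2-fold higher number from compound 2 to compound 4 (0.09 log units; within the scatter); a 1.2-fold higher number from compound 1 to compound 4 (0.06 log units; within the scatter)), so those changes show no clear difference. No measurement is available to explain the step from compound 3.

Still open, from the compounds shown here alone, is whether the ester, the ethenyl link or the fluorines account for that step. A phenyl bearing a carboxylic acid or an amine here would offer a further test.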